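The source may report more compounds than this note shows. Statements on the series, on what has been measured and on what is new or still open speak of the compounds shown alone.

Three compounds have been measured in an ADME assay on RAW264.7 cells (Mus musculus) for cytotoxicity, read by MTT assay, with a stated time of 48 h; a lower number here means a stronger inhibitor, a higher number a weaker inhibitor:

compound 1, `Cc1cc(NC(=O)c2ccc(Cl)cc2)ccc1NS(=O)(=O)C(F)(F)F`: 35400 nM
compound 2, `Cc1cc(NC(=O)c2ccc(Cl)c([N+](=O)[O-])c2)ccc1NS(=O)(=O)C(F)(F)F`: 89800 nM
compound 3, `CCS(=O)(=O)Nc1ccc(NC(=O)c2ccc(Cl)cc2)cc1F`: 152000 nM

Compound 2 differs from compound 1 by nitro in place of hydrogen on an aromatic carbon, and in this assay this change made a step of a 2.5-fold higher number from compound 1 to compound 2 (0.40 log units; beyond the scatter). Compound 3 carries a different core from compound 1; the difference between the two cores is not broken down here, and the two values simply show compound 3 at the higher number. Compound 4, `CCS(=O)(=O)Nc1ccc(NC(=O)c2ccc(Cl)c([N+](=O)[O-])c2)cc1F`, has not yet been measured. It stands to compound 3 as compound 2 stands to compound 1, differing by nitro in place of hydrogen on an aromatic carbon, the same change at the same place around it. Within the data shown here, the expectation for compound 4 therefore rests on the one measured step of this kind, that from compound 1 to compound 2 in this assay, and the expected step is a 2.1-fold higher number from compound 3 to compound 4 (0.32 log units; beyond the scatter). Compound 4 is accordingly expected to give about 320000 nM in this assay. The range judged likely for compound 4 runs from 130000 nM to 800000 nM, and since compound 3 already gives the highest of the three measured numbers, it is possible that only a limit will be reported.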

Compound 4, half-maximal inhibitory concentration: 198000 nM
The estimate for compound 4 lay 1.6-fold (0.21 log units) above the measured number; measured number inside the range.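

In this assay, nitro in place of hydrogen on an aromatic carbon, ortho to a chloro group, gave a step of a 1.3-fold higher number from compound 3 to compound 4 (0.11 log units; within the scatter), so compound 3 and compound 4 cannot be told apart on this core. Set beside the same change on the core of compound 1, the two steps cannot be distinguished from each other: the same change on two cores in this assay, a 2.5-fold higher number (0.40 log units; beyond the scatter) from compound 1 to compound 2 and a 1.3-fold higher number (0.11 log units; within the scatter) from compound 3 to compound 4, 1.9-fold (0.29 log units) apart, within the scatter of two such steps. Among these compounds, the change can therefore be carried between these two cores without a measurable difference between the steps, but this does not show that the steps are equal, since each core supplies only one pair and only the step on the core of compound 1 clears the scatter.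

The compounds shown leave open whether an amine or a carboxylic acid in place of the nitro would give a comparable step in this assay. They also leave open whether the nitro step would stay the same on a third core, such as one carrying a longer chain on the sulfonyl group.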